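This account rests on a few compounds, and the source may have more. Where it says the series, first, only, none or still open, it means among the compounds named here.

Two compounds share one core and differ only in the group attached through an oxygen on an aromatic ring. Compound 1 `CC(=O)Oc1ccc(-c2cncn2C2CCN(C(=O)c3ccc(Cl)c(C(F)(F)F)c3)CC2)cc1` carries an acetyl group there. In an assay on HEK293 cells for antagonist activity at P2X purinoceptor 7 (Homo sapiens), read by fluorescence, with a stated time of 2 h (on this read-out higher numbers stand for weaker inhibition and lower numbers for stronger inhibition), compound 1 reaches only a limit of the measurement, > 10000 nM, so no number is known for it. Compound 2 `O=C(c1ccc(Cl)c(C(F)(F)F)c1)N1CCC(n2cncc2-c2ccc(OS(=O)(=O)c3cccc4ccccc34)cc2)CC1` carries instead a sulfonyl group bearing naphthalen-1-yl. In this assay, among the compounds with values here, compound 2 gives 3520 nM, which is the only actual number among the values shown. The other value is a limit, (the limit of > 10000 nM in this assay, at which 1 of the 2 values shown sits), and it belongs to compound 1. Compound 3 `Nc1cccc(S(=O)(=O)Oc2ccc(-c3cncn3C3CCN(C(=O)c4ccc(Cl)c(C(F)(F)F)c4)CC3)cc2)c1` keeps the sulfonyl group but changes what sits on it: 3-aminophenyl in place of naphthalen-1-yl on a sulfonyl sulfur. Within the data shown here, no step between two measured compounds has been recorded here, so there is no measured guide for a change of this kind. The change is expected to produce a step of a 1.7-fold higher number from compound 2 to compound 3 (0.23 log units; within the scatter), modest and toward weaker inhibition, though it may well fall inside the usual scatter. Compound 3 is therefore estimated at 6000 nM, with a range from 2000 nM to 20000 nM, and a real chance that only a limit is reported.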

Compound 3, half-maximal inhibitory concentration: 565 nM
Beside the measured number, compound 3's estimate is 11-fold (1.03 log units) above it, and the stated range ends above it.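

In this assay, 3-aminophenyl in place of naphthalen-1-yl on the sulfonyl sulfur gives a 6.2-fold lower number from compound 2 to compound 3 (0.79 log units; beyond the scatter). This shows that the group on the sulfur can shift the number beyond the scatter, and that here a single aromatic ring carrying an amine gives stronger inhibition than the two-ring naphthalen-1-yl. Across the whole group on the oxygen, (3-aminophenyl)sulfonyl in place of acetyl gives an at least 17-fold lower number from compound 1 to compound 3 (1.24 log units; beyond the scatter), but compound 1 has only a limit of the assay and no number, so the true size of that step stays unknown: the limit of > 10000 nM in this assay, at which 1 of the 3 values shown sits.

The step from compound 2 to compound 3 removes one ring and adds the amine at once, so the two changes cannot be told apart, and a plain phenyl on the sulfonyl sulfur would be needed to separate them. Going by these compounds, it also remains open whether the amine itself matters or whether a hydroxyl or a carboxylic acid in its place on the ring would give a similar number.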